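Swapping amino for carbamoyl on a shared core

This account rests on a few compounds, and the source may have more. Where it says the series, first, only, none or still open, it means among the compounds named here.

Compound 1 `O=C(NCc1cn(-c2ccc(O)cc2)nn1)c1c[nH]c(-c2ccccc2)n1` and compound 2 `Nc1ccc(-n2cc(CNC(=O)c3c[nH]c(-c4ccccc4)n3)nn2)cc1` were both tested in an ADME assay on Vero cells (Chlorocebus sabaeus) for cytotoxicity, read by MTT assay, with a stated time of 72 h; a higher number here means a weaker inhibitor, a lower number a stronger inhibitor. In this assay compound 1 gives 281000 nM, and compound 2 gives 237000 nM. Going by the values given here, the only measured step, a 1.2-fold lower number from compound 1 to compound 2 (0.07 log units; within the scatter), lies within the scatter, so compound 2 and compound 1 cannot be told apart on these numbers. Compound 3 `NC(=O)c1ccc(-n2cc(CNC(=O)c3c[nH]c(-c4ccccc4)n3)nn2)cc1` carries one change from compound 2: carbamoyl in place of amino on an aromatic carbon. Among the compounds with values here, that earlier step is the sole guide, and it was small, so no step beyond the scatter is expected, a 1.1-fold higher number from compound 2 to compound 3 (0.02 log units; within the scatter). Compound 3 is estimated at 250000 nM, between 120000 nM and 500000 nM.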

Compound 3, half-maximal inhibitory concentration: 198000 nM
Compound 3: the middle estimate sits 1.3-fold (0.10 log units) above what was measured; the measured number falls inside the stated range.
By their numbers in this assay, from the lowest: compounds 3, 2 and 1 (each within the scatter of the next).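

Carbamoyl is a third group at this position, and it also produces no readable shift in this assay (a 1.2-fold lower number from compound 2 to compound 3 (0.08 log units; within the scatter)). Set against hydroxy, it gives the same picture (a 1.4-fold lower number from compound 1 to compound 3 (0.15 log units; within the scatter)). Hydroxy, amino and carbamoyl therefore cannot be told apart here, so exchanging these three groups at this position has no readable effect on the number.

From the compounds shown here alone, whether a carboxylic acid, a nitrile or a longer chain at this position would move the number beyond the scatter remains open. Nothing available explains why these three groups give such similar numbers.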